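Second isopropyl on the aryl ether of a thiazole amide

This account rests on a few compounds, and the source may have more. Where it says the series, first, only, none or still open, it means among the compounds named here.

Compound 1 `O=C(COc1ccccc1)Nc1nc(-c2ccc(Br)cc2)cs1` is the simplest of the three measured compounds; in a functional assay on A549 cells (Homo sapiens) for cytotoxicity, read by MTT assay, with a stated time of 48 h (a higher number here means a weaker inhibitor, a lower number a stronger inhibitor), compound 1 gives 52900 nM. Compound 2 `CC(C)c1ccccc1OCC(=O)Nc1nc(-c2ccc(Br)cc2)cs1` differs from it by isopropyl in place of hydrogen on an aromatic carbon, and in this assay compound 2 gives 48200 nM, the step being a 1.1-fold lower number from compound 1 to compound 2 (0.04 log units; within the scatter). Compound 3 `CC(C)c1ccccc1OCC(=O)Nc1nc(-c2ccc(Cl)cc2)cs1` differs from compound 2 by chloro in place of bromo, and in this assay compound 3 gives 17800 nM, a step of a 2.7-fold lower number from compound 2 to compound 3 (0.43 log units; beyond the scatter). How the core of compound 1 differs from the core of compound 3 is not broken down here.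

Compound 4 `CC(C)c1ccc(OCC(=O)Nc2nc(-c3ccc(Cl)cc3)cs2)c(C(C)C)c1` is not yet measured; it differs from compound 3 by isopropyl in place of hydrogen on an aromatic carbon. Going by the values given here, this is the same kind of change as the one between compound 1 and compound 2, not the same change: in compound 2 the isopropyl sits ortho to a large group, whereas in compound 4 it sits meta to an isopropyl group and para to a large group. Because the earlier change made a step of a 1.1-fold lower number from compound 1 to compound 2 (0.04 log units; within the scatter), compound 4 is expected to move little from compound 3, an expected step of a 1.2-fold lower number from compound 3 to compound 4 (0.07 log units; within the scatter). Compound 4 is therefore estimated at 15000 nM, within a range from 6000 nM to 40000 nM.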

Compound 4, half-maximal inhibitory concentration: 48800 nM
Compound 4: the middle estimate sits 3.3-fold (0.51 log units) below what was measured; measured number above the stated range.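

In this assay, isopropyl in place of hydrogen brought a 2.7-fold higher number from compound 3 to compound 4 (0.44 log units; beyond the scatter), and set beside the earlier step, the change did not carry over from one core to the other with the same effect: the same change on two cores in this assay, a 1.1-fold lower number (0.04 log units; within the scatter) from compound 1 to compound 2 and a 2.7-fold higher number (0.44 log units; beyond the scatter) from compound 3 to compound 4, 3.0-fold (0.48 log units) apart, beyond the scatter of two such steps The two steps are not a clean test of the core alone: the new isopropyl in compound 4 sits meta to an isopropyl group and para to a large group, a different place from the one the isopropyl takes in compound 2, and the pairs also differ in carrying bromo or chloro. With only these two pairs, the data do not show whether the place of the group, the halogen or the isopropyl already present accounts for the gap, and they give no general rule for this change across the series.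

As far as these compounds go, it remains open whether the same step would appear with bromo in place of chloro on the core of compound 4. From the compounds shown here alone, it is also open whether a smaller methyl, a methoxy or an amine at that same place would give a number closer to that of compound 3 than compound 4 does.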